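Diphenylpropanoyl acylguanidines: heteroaryl chain and phenyl count

A few compounds are considered here, and "the series" means these few. Any claim that something is new, unique, unknown or untested is made for them only; others in the source may bear on it.

Measured so far:
compound 1, `N/C(=N\C(=O)CC(c1ccccc1)c1ccccc1)NCCCc1ccncc1`, 6.14 in a functional assay on Sf9 cells for antagonist activity at histamine H2 receptor (Homo sapiens), with stated times of 2 min and 20 min; a higher number here means a more potent compound, by a factor of ten per unit of this negative logarithm, a lower number a less potent compound
compound 2, `N/C(=N\C(=O)CC(c1ccccc1)c1ccccc1)NCCCn1ccnc1`, 5.82
compound 3, `CC(CC(=O)/N=C(\N)NCCCc1ncc[nH]1)c1ccccc1`, 5.3

Compound 3 stands lowest of the three numbers. Its nearest neighbour is compound 2, whose value is higher by a margin beyond the scatter, and compound 1 lies further above it still, also beyond the scatter. For the measured compounds named here, the one step between measured compounds that differ in one place, a number 0.32 log units lower from compound 1 to compound 2 (beyond the scatter), concerns the heteroaryl end of the chain, not the acyl side, so it does not bear directly on the change considered here.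

Compound 4, `N/C(=N\C(=O)CC(c1ccccc1)c1ccccc1)NCCCc1ncc[nH]1`, has not been measured. It differs from compound 3 in one place: phenyl in place of methyl on a saturated chain carbon bound to an aromatic carbon and a saturated chain carbon. The change thus brings the acyl side of compound 4 to the diphenyl pattern shared by compound 1 and compound 2, while the imidazol-2-yl chain of compound 3 is kept. Going by the values given here, no measured pair isolates this methyl-to-phenyl exchange, so the size of the step is uncertain. Given that the two diphenyl compounds both stand above compound 3, compound 4 is expected to gain, with an estimated step of a number 0.50 log units higher from compound 3 to compound 4 (beyond the scatter). Compound 4 is therefore estimated at 5.8, within a range from 5.3 to 6.3.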

Compound 4, negative logarithm of the antagonist equilibrium constant: 6.13
Compound 4: middle estimate off by 0.33 log units, on the low side; the range from low to high includes it.
By their numbers in this assay, from the lowest: compound 3; then compound 2; then compounds 4 and 1 (each within the scatter of the next).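

In this assay, the methyl-to-phenyl exchange on a saturated chain carbon bound to an aromatic carbon and a saturated chain carbon now has a measured size with the 1H-imidazol-2-yl chain end held constant: a number 0.83 log units higher from compound 3 to compound 4 (beyond the scatter). With the diphenyl acyl side held constant, 1H-imidazol-2-yl in place of 1H-imidazol-1-yl gives a number 0.31 log units higher from compound 2 to compound 4 (beyond the scatter), so the point of attachment on the imidazole ring registers in the read-out, whereas 1H-imidazol-2-yl in place of pyridin-4-yl gives a number 0.01 log units lower from compound 1 to compound 4 (within the scatter), which leaves these two chain ends indistinguishable here. No available evidence accounts for any of these steps.

The compounds shown do not tell whether the methyl-to-phenyl step has the same size with a pyridin-4-yl or 1H-imidazol-1-yl chain end, or how an ethyl, a cyclohexyl or a benzyl group would compare with phenyl on the same carbon. They also leave open how a longer chain, or an amine in place of the heteroaryl end, would read in this assay.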